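The source may report more compounds than this note shows. Statements on the series, on what has been measured and on what is new or still open speak of the compounds shown alone.

In a functional assay on the whole organism for inhibition, with Cavia porcellus as the target (a higher number here means that more compound is needed for the effect, a lower number that less compound is needed), compound 1 (`CN(C)/C(=N\C#N)C1=CC(C)(C)Oc2ccc([N+](=O)[O-])cc21`) gives 51.3 nM. Compound 2 (`CN(C)/C(=N\C#N)C1=CC(C)(C)Oc2ccc(S(C)(=O)=O)cc21`) stands at > 31600 nM, which is a limit and not a number. Compound 3 (`CN(C)/C(=N\C#N)C1=CC(C)(C)Oc2ccc(Cl)cc21`) gives > 31600 nM, also a limit. The picture so far is the limit of > 31600 nM in this assay, at which 2 of the 3 values shown sit. Compound 4 (`CN(C)/C(=N\C#N)C1=CC(C)(C)Oc2ccccc21`) carries hydrogen in place of methylsulfonyl on an aromatic carbon. Among the measured compounds shown here, two measured steps bear on this change, an at least 610-fold higher number from compound 1 to compound 2 (2.78 log units; beyond the scatter) and an at least 610-fold higher number from compound 1 to compound 3 (2.78 log units; beyond the scatter), and both are large. The limits leave a step that the two limits leave unreadable from compound 2 to compound 3. Among these compounds only compound 1, at 51.3 nM, gives a readable value. Hydrogen is therefore not expected to restore activity, and another limit is likely. The expected change is a step that the limit leaves unreadable from compound 2 to compound 4. For compound 4 the estimate is 40000 nM, with an expected range from 8000 nM to 200000 nM.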

Compound 4, half-maximal effective concentration: > 31600 nM
Compound 4 ended at the assay's limit; the forecaster's own chance of this, stated with the estimate: 75%; the middle value lies beyond the limit too.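

Putting plain hydrogen on this aromatic carbon in place of nitro gives an at least 610-fold higher number from compound 1 to compound 4 (2.78 log units; beyond the scatter), so a compound with no group here falls short of compound 1 just as those with methylsulfonyl or chloro do. The steps among compound 2, compound 3 and compound 4 cannot be read, as all three values are limits. Of the groups shown at this position, only nitro gives a readable value: the limit of > 31600 nM in this assay, at which 3 of the 4 values shown sit.

As far as these compounds go, it remains open whether any other group here, such as an amine, a carboxylic acid or a nitrile, would also give a readable value.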